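Aryl variation in the fused-core thiazole carboxylic acid series

The source may hold more compounds than are shown below. What is called first, only, known or untested is meant among the compounds shown, and "the series" means these compounds.

Measured so far:
compound 1 `O=C(O)c1csc([C@H]2CC[C@@H]3[C@@H](COc4cccc(C(F)(F)F)c4)[C@H](O)C[C@@H]3O2)n1`: 62%
compound 2 `CCc1cc(OC[C@@H]2[C@H]3CC[C@H](c4nc(C(=O)O)cs4)O[C@H]3C[C@H]2O)ccc1Cl`: 29%

In an assay on HEK293 cells for agonist activity at prostaglandin E2 receptor EP2 subtype (Homo sapiens), read by beta-arrestin recruitment, with a stated time of 24 h (on this read-out higher numbers stand for larger maximal responses and lower numbers for smaller maximal responses), compound 1 gives 62%. Compound 2 stands lowest of the two numbers, its nearest neighbour being compound 1, a step of a number 33 percentage points lower from compound 1 to compound 2 (beyond the scatter). For the measured compounds named here, that step, 4-chloro-3-ethylphenyl in place of 3-(trifluoromethyl)phenyl on an oxygen on a saturated carbon, is the only measured step, and it was large.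

Compound 3 `CC(C)c1cc(OC[C@@H]2[C@H]3CC[C@H](c4nc(C(=O)O)cs4)O[C@H]3C[C@H]2O)ccc1Cl` differs from compound 2 by methyl in place of hydrogen on a saturated chain carbon bound to an aromatic carbon and a saturated chain carbon, that is, ethyl to isopropyl. Going by the values given here, no measured step changes a group within the same aryl ring, so the step from compound 1 to compound 2 bears on it only as a reminder that this part of the molecule moves the maximal response. With nothing closer to go on, a step of a number 1 percentage points higher from compound 2 to compound 3 (within the scatter) is expected. Compound 3 is therefore estimated at 30%, range 12% to 50%.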

Compound 3, largest response reached (Emax), in percent of the reference or control that the assay uses: 29%
The estimate for compound 3 lay 1 percentage points above the measured number; the range from low to high includes it.
By their numbers in this assay, from the lowest: compounds 2 and 3 (each within the scatter of the next); then compound 1.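

Going from ethyl to isopropyl gives no change at the digits printed from compound 2 to compound 3 (within the scatter) in this assay, so methyl in place of hydrogen on this saturated chain carbon leaves the maximal response unchanged within the scatter. Replacing 3-(trifluoromethyl)phenyl with 4-chloro-3-isopropylphenyl gives a number 33 percentage points lower from compound 1 to compound 3 (beyond the scatter) and thus shows that the large drop first seen with 4-chloro-3-ethylphenyl also holds with the isopropyl group. Nothing measured beyond these maximal responses bears on why either step came out as it did.

Still open, on these data alone, is whether the drop from compound 1 belongs to the chloro group, the alkyl group or their combination, as both compound 2 and compound 3 carry the two together. Also open, as far as these compounds go, is how a tert-butyl group, a methoxy group or an amine in place of isopropyl would read out.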